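A few compounds are considered here, and "the series" means these few. Any claim that something is new, unique, unknown or untested is made for them only; others in the source may bear on it.

Compound 1 `CCCOc1nc(N)nc2c1ncn2/C=C1/CC1(CO)CO` is the starting point. In an ADME assay on CCRF-HSB-2 cells (Homo sapiens) for cytotoxicity, with a stated time of 7 days (on this read-out lower numbers stand for higher toxicity in this test and higher numbers for lower toxicity in this test), compound 1 gives > 20000 nM, which is a limit of the assay and not a number. Compound 2 `CSc1nc(N)nc2c1ncn2/C=C1/CC1(CO)CO` differs from it in one place. In this assay compound 2 gives > 100000 nM, again a limit. Compound 3 `Nc1nc(OCc2ccccc2)c2ncn(/C=C3/CC3(CO)CO)c2n1` is the third measured member. In this assay compound 3 gives > 20000 nM, also a limit. Since every value sits at the limit of > 20000 nM in this assay, at which 2 of the 3 values shown sit, or at the limit of > 100000 nM in this assay, at which 1 of the 3 values shown sits, the steps a step that the two limits leave unreadable from compound 1 to compound 2, a step that the two limits leave unreadable from compound 1 to compound 3 and a step that the two limits leave unreadable from compound 2 to compound 3 cannot be given a size. Compound 4 `C=CCOc1nc(N)nc2c1ncn2/C=C1/CC1(CO)CO` is not yet measured; it differs from compound 1 by vinyl in place of ethyl on a saturated chain carbon bound to an oxygen on an aromatic ring. Among the compounds with values here, no measured step bears on this change in a readable way, so no direction can be drawn from them, and the three limits only suggest that compound 4 may once more sit at a limit. Compound 4 is expected to give 30000 nM, with a range from 10000 nM to 100000 nM. The expected step is a step that the limit leaves unreadable from compound 1 to compound 4, that is none beyond the scatter.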

Compound 4, half-maximal cytotoxic concentration: > 20000 nM
Compound 4: no number, only a limit (the forecaster's own chance of this, stated with the estimate: 80%); the middle value does not contradict the limit.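

Compound 4, like compound 1, compound 2 and compound 3, gives only a limit and no number in this assay, and the steps from those three to compound 4 cannot be read. The compounds shown leave open whether propoxy, allyloxy, benzyloxy and methylsulfanyl differ at all in this read-out.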